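Swapping the thiazole for a fluorophenyl oxadiazole

The source may hold more compounds than are shown below. What is called first, only, known or untested is meant among the compounds shown, and "the series" means these compounds.

Compound 2 `Cc1noc(C)c1-c1ccc2c(c1)C(c1ccccc1)N(Cc1csc(-c3ccc(F)cc3)n1)C(=O)N2C` is one of two measured members of the series. In a functional assay on U-266 cells (Homo sapiens) for inhibition, read by MTT assay, with a stated time of 48 h, tested at 0.1 uM (on this read-out higher numbers stand for more inhibition at the one concentration tested (going by the name of the read-out) and lower numbers for less inhibition), compound 2 gives 8.4%, and compound 1 `Cc1noc(C)c1-c1ccc2c(c1)C(c1ccccc1)N(Cc1nc(-c3ccccc3)cs1)C(=O)N2C` gives 12.7%; the two sit within the scatter of each other, the step being a number 4.3 percentage points lower from compound 1 to compound 2 (within the scatter). Compound 3 `Cc1noc(C)c1-c1ccc2c(c1)C(c1ccccc1)N(Cc1nnc(-c3ccc(F)cc3)o1)C(=O)N2C` is unmeasured. It differs from compound 2 by 5-(4-fluorophenyl)-1,3,4-oxadiazol-2-yl in place of 2-(4-fluorophenyl)-1,3-thiazol-4-yl on a saturated chain carbon bound to an amide-type nitrogen in a ring. For the measured compounds named here, the only measured step exchanges one thiazole arrangement for another with a fluorophenyl group at the same place, and it stays within the scatter; no step bears on the oxadiazole itself. Both measured numbers lie low in this assay. Compound 3 is therefore expected to give about 9%, within roughly 0% to 22%, and the expected change from compound 2 is a number 0.6 percentage points higher from compound 2 to compound 3 (within the scatter), not beyond the scatter.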

Compound 3, a percentage reported as inhibition, at one concentration (the size of the read-out at that concentration, not a potency): 26.8%
The estimate for compound 3 lay 17.8 percentage points below the measured number; measured number above the stated range.
By their numbers in this assay, from the lowest: compounds 2 and 1 (each within the scatter of the next); then compound 3.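

Working notes: this position is not indifferent to the ring placed on it, even though the two thiazole arrangements gave numbers within the scatter of each other. In this assay the exchange of 2-(4-fluorophenyl)-1,3-thiazol-4-yl for 5-(4-fluorophenyl)-1,3,4-oxadiazol-2-yl gives a number 18.4 percentage points higher from compound 2 to compound 3 (beyond the scatter) and the exchange of 4-phenyl-1,3-thiazol-2-yl for the same oxadiazole gives a number 14.1 percentage points higher from compound 1 to compound 3 (beyond the scatter), so the oxadiazole stands apart from both thiazoles at this single concentration. Nothing available explains this difference.

Open, going by these compounds, is how much of the higher number depends on the 4-fluorophenyl group carried by the oxadiazole, and whether it would survive an amine or a carboxylic acid on that phenyl ring. Also open, on these data alone, is the effect of a longer chain in place of the saturated chain carbon.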